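The source may report more compounds than this note shows. Statements on the series, on what has been measured and on what is new or still open speak of the compounds shown alone.

Compound 1 `COc1ccc2oc(C(c3ccccc3)c3c[nH]c4ccccc34)cc2c1` gives only a limit in a functional assay on SiHa cells (Homo sapiens) for cytotoxicity (a lower number here means a stronger inhibitor, a higher number a weaker inhibitor), > 100000 nM. Compound 2 `COc1ccc2oc(C(c3ccccc3)c3c(C)[nH]c4ccccc34)cc2c1` likewise gives only a limit in this assay, > 100000 nM. Compound 3 `COc1ccc(C(c2cc3ccccc3o2)c2c[nH]c3ccccc23)cc1` also gives only a limit in this assay, > 100000 nM.

The change from compound 1 to compound 2 is methyl in place of hydrogen on an aromatic carbon. The step it made, a step that the two limits leave unreadable from compound 1 to compound 2, cannot be read because of the limit of > 100000 nM in this assay, at which 3 of the 3 values shown sit. Compound 4 `COc1ccc(C(c2cc3ccccc3o2)c2c(C)[nH]c3ccccc23)cc1` carries the same change on the core of compound 3, (methyl in place of hydrogen on an aromatic carbon), the place described in the same words. How the core of compound 3 differs from that of compound 1 is not broken down here. For compound 4 the step expected is a number no higher from compound 3 to compound 4 (the limit leaves the size open), resting on compound 3 sitting at a limit and on the unreadable step before it. Compound 4 is thus expected to give 100000 nM in this assay.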

Compound 4, half-maximal inhibitory concentration: > 100000 nM
Compound 4: only a limit was reported; the forecaster's own chance of this, stated with the estimate: 85%; the middle value sits exactly at the limit.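

No step can be read between compound 3 and compound 4 in this assay, as each gives only a limit: the limit of > 100000 nM in this assay, at which 4 of the 4 values shown sit.

The compounds shown leave open how strong any of them is, and whether methyl in place of hydrogen changes that at all.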